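The compounds below may be only part of what the source reports. "The series", "measured", "known", "first", "only" and "open" are said of these compounds alone.

Measured compounds in an assay on isolated protein with Bile acid receptor (Homo sapiens) as the target; a higher number here means that more compound is needed for the effect, a lower number that less compound is needed:
compound 1, `COC(=O)/C=C/c1cccc(N(Cc2ccc(/C=C/c3ccccc3F)cc2)C(=O)C2CCCCC2)c1`: 64 nM
compound 2, `COC(=O)/C=C/c1cccc(N(Cc2ccc(/C=C/c3ccccn3)cc2)C(=O)C2CCCCC2)c1`: 309 nM
compound 3, `COC(=O)/C=C/c1cccc(N(Cc2ccc(/C=C/c3scnc3C)cc2)C(=O)C2CCCCC2)c1`: 227 nM

Compound 3 holds the second highest of the three numbers: the step of a 1.4-fold lower number from compound 2 to compound 3 (0.13 log units; within the scatter) is small, whereas the step of a 3.5-fold higher number from compound 1 to compound 3 (0.55 log units; beyond the scatter) is clear. Compound 4, `COC(=O)/C=C/c1cccc(N(Cc2ccc(-c3ccc(OC)cc3)cc2)C(=O)C2CCCCC2)c1`, differs from compound 3 by 4-methoxyphenyl in place of 2-(4-methyl-1,3-thiazol-5-yl)ethenyl on an aromatic carbon. Going by the values given here, no measured step replaces the ethenyl-linked group by a ring bound directly to the core, so the change is not covered well. Among the compounds with values here, the steps of a 4.8-fold higher number from compound 1 to compound 2 (0.68 log units; beyond the scatter) and a 3.5-fold higher number from compound 1 to compound 3 (0.55 log units; beyond the scatter) show only that exchanging the ring at the end of the double bond moved the number by modest amounts. The expected step of a 1.5-fold higher number from compound 3 to compound 4 (0.19 log units; within the scatter) is accordingly taken as small, with its direction uncertain. Compound 4 is estimated at 350 nM, within a range from 70 nM to 1800 nM.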

Compound 4, half-maximal effective concentration: 89 nM
Compound 4: middle estimate off by 3.9-fold (0.59 log units), on the high side, and the stated range covers the measured number.
By their numbers in this assay, from the lowest: compounds 1 and 4 (each within the scatter of the next); then compounds 3 and 2 (each within the scatter of the next).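

In this assay, a ring bound directly at this aromatic carbon, para to a large group, can do as well as a ring held on an ethenyl link. Placing 4-methoxyphenyl there gives a 2.6-fold lower number from compound 3 to compound 4 (0.41 log units; beyond the scatter) and a 3.5-fold lower number from compound 2 to compound 4 (0.54 log units; beyond the scatter), while the change from the 2-(2-fluorophenyl)ethenyl group stays small (a 1.4-fold higher number from compound 1 to compound 4 (0.14 log units; within the scatter)). Nothing measured here explains these differences. Open, as far as these compounds go, is whether a plain phenyl or a 4-hydroxyphenyl at this place would give a similar number, and what 2-fluorophenyl would give when bound directly, without the double bond.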